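Sulfonyl tail variation: neopentyl replaced by methoxycarbonyl

A few compounds are considered here, and "the series" means these few. Any claim that something is new, unique, unknown or untested is made for them only; others in the source may bear on it.

Three compounds on the shared core have been run in an ADME assay on microsomes from liver (Rattus norvegicus) for metabolic stability, with a stated time of 10 min; on this read-out lower numbers stand for a less stable compound and higher numbers for a more stable compound. Compound 1 `O=C(NS(=O)(=O)CCNC(=O)C1CC1)c1ccc(Nc2nc(NC3(c4ccc(Cl)cc4)CC3)nc(OCC(F)(F)F)n2)cc1` came back as "not active" (no number reported) without a number. Compound 2 `O=C(NS(=O)(=O)c1ccccc1)c1ccc(Nc2nc(NC3(c4ccc(Cl)cc4)CC3)nc(OCC(F)(F)F)n2)cc1` gives 100%, and compound 3 `CC(C)(C)CNCCS(=O)(=O)NC(=O)c1ccc(Nc2nc(NC3(c4ccc(Cl)cc4)CC3)nc(OCC(F)(F)F)n2)cc1` gives 90%. For the measured compounds named here, the one single-point step on record, a number 10 percentage points lower from compound 2 to compound 3 (within the scatter), changes the substituent on the sulfonyl sulfur and stays within the scatter; compound 3 thus sits close to compound 2 on the two numbers available, with compound 1 contributing no number.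

Compound 4 `COC(=O)NCCS(=O)(=O)NC(=O)c1ccc(Nc2nc(NC3(c4ccc(Cl)cc4)CC3)nc(OCC(F)(F)F)n2)cc1` is the next point: methoxycarbonyl in place of neopentyl on an amine nitrogen. Going by the values given here, no measured step makes this exchange; the step from compound 2 to compound 3 is the nearest in kind, since it also alters the chain on the sulfonyl side, and it was within the scatter. On that basis no step beyond the scatter is expected in this assay, and the expected change is a number 5 percentage points lower from compound 3 to compound 4 (within the scatter). For compound 4 the estimate is 85%, with a range from 60% to 100%.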

Compound 4, percent of the compound remaining: 100%
Compound 4: the middle estimate sits 15 percentage points below what was measured, within the range that was stated.
By their numbers in this assay, from the lowest: compounds 3, 2 and 4 (each within the scatter of the next).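

Within this assay, an all-carbon neopentyl on the amine nitrogen can give way to methoxycarbonyl, which brings in oxygen and a carbonyl, with a number 10 percentage points higher from compound 3 to compound 4 (within the scatter). On the sulfonyl sulfur, 2-((methoxycarbonyl)amino)ethyl in place of phenyl gives no change at the digits printed from compound 2 to compound 4 (within the scatter), so this read-out now tolerates a second, differently capped chain at that position without a step beyond the scatter. No measurement on hand accounts for these results.

Compound 1 gives "not active" (no number reported) and so cannot be placed among these numbers, which leaves the reach of this tolerance across capped chains unsettled. Going by these compounds, whether a primary amine or a carboxylic acid at the end of the chain, or a longer chain on the sulfonyl sulfur, would also stay within the scatter remains open.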